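Swapping Chloro for Fluoro: What to Expect for Compound 4

The source may hold more compounds than are shown below. What is called first, only, known or untested is meant among the compounds shown, and "the series" means these compounds.

Of the compounds shown here, three built on one shared core have been tested in a functional assay on NCI-H292 cells (Homo sapiens) for cytotoxicity, read by MTT assay, with a stated time of 72 h, tested at 2.5 ug/mL; on this read-out lower numbers stand for less inhibition of growth and higher numbers for more inhibition of growth at the one concentration tested. Compound 1 `O=C1NC(=S)/C(=C/c2ccc(Cl)cc2)S1` gives 28.6%. Compound 3 `O=C1NC(=S)/C(=C/c2ccc(F)cc2)S1` gives 17.5% in this assay, and the change from compound 1 to compound 3, (fluoro in place of chloro on an aromatic carbon), made a step of a number 11.1 percentage points lower from compound 1 to compound 3 (beyond the scatter). Compound 2 `O=C1NC(=S)/C(=C/c2ccccc2Cl)S1` has the same atoms as compound 1, joined differently; the difference between the two cores is not broken down here. In this assay compound 2 gives 19.9%. Compound 4 `O=C1NC(=S)/C(=C/c2ccccc2F)S1` has not yet been measured; it differs from compound 2 by fluoro in place of chloro on an aromatic carbon. This is the same kind of change as that from compound 1 to compound 3, yet the place is not the same: in compound 3 the fluoro sits para to a group of 8 heavy atoms, whereas in compound 4 it sits ortho to a group of 8 heavy atoms. Because the earlier step was a number 11.1 percentage points lower from compound 1 to compound 3 (beyond the scatter), a step in the same direction is expected, a number 7.9 percentage points lower from compound 2 to compound 4 (within the scatter), made smaller for the different place. Compound 4 is therefore estimated at 12% in this assay, between 0% and 26%.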

Compound 4, percent growth inhibition at one concentration: 7.78%
Estimate against measurement, compound 4: 4.2 percentage points above; measured number inside the range.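

In this assay, putting fluoro in place of chloro on an aromatic carbon gave a number 12.1 percentage points lower from compound 2 to compound 4 (beyond the scatter). Within the data shown here, the swap therefore lowered growth inhibition on both cores, and the two steps are about the same size, even though the fluoro of compound 4 sits ortho to a group of 8 heavy atoms and the two cores are joined differently: the same change on two cores in this assay, a number 11.1 percentage points lower (beyond the scatter) from compound 1 to compound 3 and a number 12.1 percentage points lower (beyond the scatter) from compound 2 to compound 4, 1 percentage points apart, within the scatter of two such steps This is a match between only two pairs at a single concentration, so it does not show that the step would hold on other cores or at other places on the ring, and it does not explain why the number falls.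

The compounds shown carry only chloro or fluoro on the aromatic ring, so it remains open how a bromo, a methoxy, an amine or a carboxylic acid would compare there. Also open, going by these compounds, is how a ring with plain hydrogen in place of the halogen would behave in this assay.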